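The compounds below may be only part of what the source reports. "The series", "measured", "known", "first", "only" and "open" are said of these compounds alone.

Measured compounds and their readings:

Compound 1, `CCOC(=O)c1cc2ccc(OCCCn3cc(CNC(=O)CCCCC4CCSS4)nn3)cc2oc1=O`, gives 36.1%.
Compound 2, `O=C(CCCCC1CCSS1)NCc1cn(CCCCOc2ccc3cc(-c4ccc(Br)cc4)c(=O)oc3c2)nn1`, gives 42.6%.
Compound 3, `CCOC(=O)c1cc2ccc(OCCCCCn3cc(CNC(=O)CCCCC4CCSS4)nn3)cc2oc1=O`, gives 38.3%.

All three readings come from a functional assay on PC-12 cells (Rattus norvegicus) for cytotoxicity, read by MTT assay, with stated times of 3 h and 2 h, tested at 10 uM; a lower number here means a weaker effect, a higher number a stronger effect of the compound at the concentration tested. Among them compound 3 is the second highest of three numbers, but its nearest neighbour is compound 1, whose reading lies within the scatter of repeated measurements, and its furthest neighbour, compound 2, also lies within that scatter. In this assay, then, the three measured compounds cannot be told apart, and no ranking among them is warranted.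

Compound 4, `O=C(CCCCC1CCSS1)NCc1cn(CCCCCOc2ccc3cc(-c4ccc(Br)cc4)c(=O)oc3c2)nn1`, has not yet been measured in this assay. It is obtained from compound 3 by a single change: 4-bromophenyl in place of ethoxycarbonyl on an aromatic carbon. Compound 2 already carries the 4-bromophenyl group on the shared core, with a shorter chain than compound 4, and its reading and that of compound 3 differ by less than the scatter. Within the data shown here, no measured pair isolates this change on its own, so there is no directly comparable step to draw on.

On that basis, compound 4 is expected to show a step from compound 3 of a number 2.7 percentage points higher from compound 3 to compound 4 (within the scatter), no larger than the scatter in either direction. The estimate for compound 4 in this assay is 41%, with a range from 30% to 52%.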

Compound 4, a percentage reported as activity, at one concentration (the size of the read-out at that concentration, not a potency): 48.4%
Compound 4: the middle estimate sits 7.4 percentage points below what was measured, within the range that was stated.
By their numbers in this assay, from the lowest: compounds 1, 3, 2 and 4 (each within the scatter of the next, the first and the last beyond it).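

In this assay, placing 4-bromophenyl in place of ethoxycarbonyl on this aromatic carbon, with the rest of compound 3 unchanged, gives a number 10.1 percentage points higher from compound 3 to compound 4 (beyond the scatter). This is the first pair among the compounds shown that isolates a single change, and it shows that the reading responds to what sits at this position on the shared core, where the earlier three compounds could not be told apart. Nothing measured here accounts for the step, so it stands as an observation from one pair, without an explanation.

The compounds shown leave open whether the ring or the bromine carries the step, as neither an unsubstituted phenyl nor a 4-chlorophenyl group appears at this position, and a carboxylic acid or an amide there would test how far the ester itself matters. Among these compounds, they also leave open whether the same exchange gives a step of similar size on a shorter chain, as no pair with a shorter chain differs in this place alone.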